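Series notes: from compound 3 to compound 4

The compounds below may be only part of what the source reports. "The series", "measured", "known", "first", "only" and "open" are said of these compounds alone.

Compound 3 `O=C(O)Cc1sc(C(c2ccccc2)c2ccccc2)nc1-c1ccc(F)c(F)c1` gives the lowest of the three numbers measured in an in vitro assay on HEK385-7 cells for displacement of a labelled ligand from prostaglandin D2 receptor 2 (Homo sapiens) (on this read-out higher numbers stand for weaker inhibition and lower numbers for stronger inhibition), at 4.1 nM. Compound 2 `O=C(O)Cc1sc(C(c2ccccc2)c2ccccc2)nc1-c1ccc(F)cc1` gives 8.7 nM in this assay, and a 2.1-fold lower number from compound 2 to compound 3 (0.33 log units; beyond the scatter). Compound 1 `O=C(O)Cc1sc(CS(=O)(=O)c2ccc(Cl)cc2)nc1-c1ccc(Cl)cc1` gives 1500 nM in this assay; it differs from compound 3 in two places, and the two numbers simply stand far apart, with compound 1 much weaker.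

Compound 4 `COc1ccc(OC)c(-c2nc(C(c3ccccc3)c3ccccc3)sc2CC(=O)O)c1` is not yet measured. The change is 2,5-dimethoxyphenyl in place of 3,4-difluorophenyl on an aromatic carbon. Within the data shown here, the only measured step on the same ring is the one from compound 2 to compound 3, and it was modest; nothing measured carries methoxy groups on that ring, and the entering group brings two hydrogen-bond acceptors where the leaving group had none. Resting on a 2.1-fold lower number from compound 2 to compound 3 (0.33 log units; beyond the scatter) alone, the expected step is of moderate size and uncertain direction, a 4.9-fold higher number from compound 3 to compound 4 (0.69 log units; beyond the scatter), with a somewhat higher number judged more likely. Compound 4 is estimated at 20 nM, with a range from 4 nM to 100 nM in this assay.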

Compound 4, half-maximal inhibitory concentration: > 105 nM
Compound 4: no number, only a limit; the forecaster's own chance of this, stated with the estimate: 2%; middle value at least 5.2-fold (0.72 log units) away from the limit.
By their numbers in this assay, from the lowest: compound 3; then compound 2; then compound 1.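

Compound 4 gives no number in this assay, only a limit of the assay: the limit of > 105 nM in this assay, at which 1 of the 4 values shown sits.

Placing 2,5-dimethoxyphenyl on the aromatic carbon next to the ring nitrogen gives an at least 25-fold higher number from compound 3 to compound 4 (1.40 log units; beyond the scatter) and an at least 12-fold higher number from compound 2 to compound 4 (1.08 log units; beyond the scatter), both large, whereas the only earlier step on this ring, a 2.1-fold lower number from compound 2 to compound 3 (0.33 log units; beyond the scatter), was modest. The aryl group at this position can therefore change the read-out far more than the two fluorinated compounds showed.

The change swaps the whole substituted ring, so the compounds shown cannot separate the effect of the methoxy groups from that of where they sit or of losing the fluoro groups. From the compounds shown here alone, whether a single methoxy group or a hydroxy group on this ring would cost as much remains open, as does how far the true value of compound 4 lies beyond its limit.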